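Methoxy in place of methyl: an expected small step

The compounds below may be only part of what the source reports. "The series", "measured", "known", "first", "only" and "open" are said of these compounds alone.

Measured so far in a functional assay on HeLa cells (Homo sapiens) for antiproliferative activity, read by MTT assay; on this read-out higher numbers stand for weaker inhibition and lower numbers for stronger inhibition:
Compound 1 `O=[N+]([O-])c1ccc(Nc2nccc(-c3ccc(F)cc3)n2)cc1`: 3510 nM
Compound 2 `Cc1cccc(Nc2nccc(-c3ccc(Cl)cc3Cl)n2)c1`: 7660 nM

Of the two measured compounds, compound 2 stands at the higher number, and so at the weaker inhibition. Its gap to compound 1 lies beyond the usual scatter, but the two differ in more than one place, so that gap says nothing about any single change.

Compound 3 `COc1cccc(Nc2nccc(-c3ccc(Cl)cc3Cl)n2)c1` has methoxy in place of methyl on an aromatic carbon, meta to a large group (methoxy in place of methyl on an aromatic carbon). Going by the values given here, no measured pair shows this change, so the expectation starts from compound 2 at 7660 nM. In this assay, no step beyond the scatter is expected, and no direction can be claimed with confidence. The estimated step of a 1.3-fold lower number from compound 2 to compound 3 (0.11 log units; within the scatter) stays within that scatter. For compound 3 the estimated value is 6000 nM, with an expected range from 2500 nM to 15000 nM.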

Compound 3, half-maximal inhibitory concentration: 76400 nM
Compound 3: middle estimate off by 13-fold (1.10 log units), on the low side; measured number outside the range, above it.
By their numbers in this assay, from the lowest: compound 1; then compound 2; then compound 3.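

In this assay, methoxy in place of methyl on an aromatic carbon, meta to a large group, brings a 10-fold higher number from compound 2 to compound 3 (1.00 log units; beyond the scatter) and so moves toward weaker inhibition. Going by these compounds alone, this is the first comparison here that isolates a single change, and it shows that this position is not indifferent to the swap, which the gap between compound 1 and compound 2 could not show. Nothing measured here accounts for the step and the cause stays unassigned.

With only methyl and methoxy shown at this place, the compounds leave open whether the weaker inhibition follows the oxygen or the added heavy atom, a question that a hydroxyl group or an ethyl group there could help to separate. They also leave open whether the same change would give a similar step on the other substitution pattern of compound 1.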